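The source may report more compounds than this note shows. Statements on the series, on what has been measured and on what is new or still open speak of the compounds shown alone.

Compound 1 `CN1CCN(c2ccc(Nc3nc(-c4cccc(NC(=O)c5ccc(C(C)(C)C)cc5)c4)sc3C(N)=O)cc2)CC1`: "not determined" (no result reported) in a functional assay on Raji cells (Homo sapiens) for antiproliferative activity, read by CCK-8 assay, with a stated time of 72 h; on this read-out higher numbers stand for weaker inhibition and lower numbers for stronger inhibition
Compound 2 `CN1CCN(c2ccc(Nc3nc(-c4cccc(NC(=O)c5ccc(C(F)(F)F)cn5)c4)sc3C(N)=O)cc2)CC1`: 24500 nM
Compound 3 `CN1CCN(c2ccc(Nc3nc(-c4cccc(NC(=O)c5ccco5)c4)sc3C(N)=O)cc2)CC1`: not yet measured

Within the data shown here, compound 2 stands as the only entry with a number in this assay; for compound 1 no result was reported, so no comparison between them is possible. Compound 2 itself is a weak inhibitor on this read-out. Compound 3 differs from compound 2 in one place: furan-2-yl in place of 5-(trifluoromethyl)pyridin-2-yl on a carbonyl carbon. Among the measured compounds shown here, no measured pair shows what such an exchange does on this shared core, so the direction of the step is open. Compound 3 is expected to stay near the weak activity of compound 2, and the step is estimated as a 1.2-fold higher number from compound 2 to compound 3 (0.09 log units; within the scatter), probably not beyond the scatter. For compound 3 the expected value in this assay is 30000 nM, with a range from 8000 nM to 100000 nM.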

Compound 3, half-maximal inhibitory concentration: 37400 nM
Compound 3: the middle estimate sits 1.2-fold (0.10 log units) below what was measured; low and high end bracket the measured number.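

Among these compounds, measured in this assay, the exchange of 5-(trifluoromethyl)pyridin-2-yl for furan-2-yl on a carbonyl carbon gives a 1.5-fold higher number from compound 2 to compound 3 (0.18 log units; within the scatter), the first step that can be read at this position. Replacing the six-membered aromatic ring and its trifluoromethyl with a five-membered aromatic ring therefore leaves the number where it was, and both compounds remain weak inhibitors on this read-out. Nothing in the data explains this result.

Both groups shown here are aromatic rings with one hetero atom, so it remains open whether a piperidine or a short alkyl chain on this carbonyl carbon would move the number beyond the scatter. The compounds with numbers also leave open what an amine or a carboxylic acid would do elsewhere on the shared core.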